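A few compounds are considered here, and "the series" means these few. Any claim that something is new, unique, unknown or untested is made for them only; others in the source may bear on it.

Compound 1 `CS(=O)(=O)c1ccc(C(=O)N2CCC(N(C3CC3)S(=O)(=O)c3cccc(C(F)(F)F)c3)CC2)c(Cl)c1`: 290 nM
Compound 2 `CS(=O)(=O)c1ccc(C(=O)N2CCC(N(C3CC3)S(=O)(=O)c3cccc(C(F)(F)F)c3)CC2)c(C(F)(F)F)c1`: 21 nM

In an assay on HEK293 cells for inhibition of Voltage-dependent N-type calcium channel subunit alpha-1B (Homo sapiens), read by FLIPR and calcium flux (a higher number here means a weaker inhibitor, a lower number a stronger inhibitor), compound 1 gives 290 nM, and compound 2 gives 21 nM. Among the compounds with values here, compound 2 therefore stands at the lower of the two numbers measured so far, and the one step measured, a 14-fold lower number from compound 1 to compound 2 (1.14 log units; beyond the scatter), comes from putting trifluoromethyl in place of chloro on an aromatic carbon of the shared core.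

Compound 3 `NC(=O)c1ccc(C(=O)N2CCC(N(C3CC3)S(=O)(=O)c3cccc(C(F)(F)F)c3)CC2)c(C(F)(F)F)c1` differs from compound 2 in one place: carbamoyl in place of methylsulfonyl on an aromatic carbon. Within the data shown here, no measured step covers this change; the single step available concerns a different group at a different place, so it gives no guide to the direction or size of what this exchange will do. With nothing to suggest a large shift either way, the expected step is a 2.1-fold higher number from compound 2 to compound 3 (0.33 log units; beyond the scatter). Compound 3 is thus estimated to give about 45 nM in this assay, with a likely range from 12 nM to 180 nM.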

Compound 3, half-maximal inhibitory concentration: 760 nM
Beside the measured number, compound 3's estimate is 17-fold (1.23 log units) below it, and the stated range ends below it.
By their numbers in this assay, from the lowest: compound 2; then compound 1; then compound 3.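

At this position, para to a large group and meta to a trifluoromethyl group, replacing methylsulfonyl with carbamoyl in this assay gives a 36-fold higher number from compound 2 to compound 3 (1.56 log units; beyond the scatter), so a second place on the shared core is now seen to respond strongly to a single exchange. The leaving methylsulfonyl has 0 hydrogen-bond donors and 2 hydrogen-bond acceptors, while the entering carbamoyl has 1 of each. No measurement here explains the rise in the number.

On these data alone, whether the amide hydrogens matter remains open, and a nitrile or a carbamoyl with two methyl groups on its nitrogen at this position would help test that. As far as these compounds go, it is also open whether the change seen in a 14-fold lower number from compound 1 to compound 2 (1.14 log units; beyond the scatter) would hold with carbamoyl at this position in place of methylsulfonyl.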